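Trimming the Cyclopentyl to Isopropyl Beside the Carbonyl

The source may hold more compounds than are shown below. What is called first, only, known or untested is meant among the compounds shown, and "the series" means these compounds.

Of the compounds shown here, two have so far been measured in an assay on HEK293 cells for positive allosteric modulation of metabotropic glutamate receptor 3 (Rattus norvegicus), read by thallium flux, with a stated time of 2.5 min; on this read-out lower numbers stand for smaller maximal responses and higher numbers for larger maximal responses. Compound 1 `Cc1c(OCCCCOCOc2ccc(C(=O)O)cc2)ccc(C(=O)CC2CCCC2)c1O` gives 46.9% in this assay. Compound 2 `Cc1c(OCCCCOc2ccc(C(=O)O)cc2F)ccc(C(=O)CC2CCCC2)c1O` gives 31.2% in this assay and stands as the lower of the two numbers, with compound 1 as its nearest neighbour through the step of a number 15.7 percentage points lower from compound 1 to compound 2 (beyond the scatter). That step concerns a different part of the structure, where 4-carboxy-2-fluorophenyl replaced (4-carboxyphenoxy)methyl on an oxygen on a saturated carbon.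

Compound 3 `Cc1c(OCCCCOc2ccc(C(=O)O)cc2F)ccc(C(=O)CC(C)C)c1O` has not yet been measured. It differs from compound 2 on the saturated chain carbon bound to a carbonyl carbon: isopropyl in place of cyclopentyl on a saturated chain carbon bound to a carbonyl carbon. Going by the values given here, no measured step touches this part of the structure, so the two numbers at hand give no direct guide to either the size or the direction of the change. Without a comparable step, compound 3 is expected to stay close to compound 2, and the step of a number 0.2 percentage points lower from compound 2 to compound 3 (within the scatter) is expected to remain within the scatter. The estimate for compound 3 in this assay is 31%, expected to lie between 14% and 50%.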

Compound 3, largest response reached (reported as percent of maximum), in percent of the reference or control that the assay uses: 67.7%
Compound 3: the middle estimate sits 36.7 percentage points below what was measured; measured number outside the range, above it.
By their numbers in this assay, from the lowest: compound 2; then compound 1; then compound 3.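

In this assay, going by these compounds alone, the saturated chain carbon bound to a carbonyl carbon proves to be a responsive place, which the earlier compounds could not show, since their only step lay in a different part of the structure: a number 36.5 percentage points higher from compound 2 to compound 3 (beyond the scatter). The change exchanges cyclopentyl, with its five-membered ring of carbon only and 5 heavy atoms, for isopropyl, with no ring and 3 heavy atoms, while neither group carries a hydrogen-bond donor, a hydrogen-bond acceptor or a net charge. Nothing available bears on why the number rises, so the step stands as an observation on this one pair.

A single pair cannot separate the loss of the ring from the loss of heavy atoms, and a cyclobutyl ring or an n-propyl chain at this place would speak to that question. As far as these compounds go, it also remains open whether isopropyl in place of cyclopentyl would give a step of similar size with the (4-carboxyphenoxy)methyl group of compound 1 at the other end of the molecule.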